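Swapping a chlorophenyl for a hydroxy-methoxyphenyl on a shared core

The source may report more compounds than this note shows. Statements on the series, on what has been measured and on what is new or still open speak of the compounds shown alone.

Compound 1 `COc1cccc(/C=C2\CCC/C(=C\c3cccc(OC)c3OC)C2=O)c1`: 16400 nM
Compound 2 `COc1cccc(/C=C2\CCC/C(=C\c3cc(OC)c(OC)c(OC)c3)C2=O)c1OC`: 5900 nM
Compound 3 `COc1ccc(/C=C2\CCC/C(=C\c3cccc(Cl)c3)C2=O)cc1OC`: 11000 nM

In a functional assay on A549 cells (Homo sapiens) for cytotoxicity, read by MTT assay, with a stated time of 72 h (a higher number here means a weaker inhibitor, a lower number a stronger inhibitor), compound 3 gives 11000 nM, the second highest of the three numbers. Its nearest neighbour is compound 1, whose value lies within the usual scatter of it, and its furthest is compound 2, whose value also lies within that scatter, so compound 3 is not separated from either of them.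

Compound 4 `COc1cc(/C=C2\CCC/C(=C\c3ccc(OC)c(OC)c3)C2=O)ccc1O` has not yet been measured. It differs from compound 3 in one place: 4-hydroxy-3-methoxyphenyl in place of 3-chlorophenyl on a double-bonded chain carbon bound to a double-bonded ring carbon

Within the data shown here, no pair of measured compounds with a single difference is available to size this kind of change, so the step is expected to be small, none beyond the scatter, with a slight lean to a lower number for compound 4, giving a 1.4-fold lower number from compound 3 to compound 4 (0.14 log units; within the scatter) as the expected step.

Compound 4 is therefore estimated at 8000 nM, in a range from 3000 nM to 25000 nM.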

Compound 4, half-maximal inhibitory concentration: 10300 nM
The estimate for compound 4 lay 1.3-fold (0.11 log units) below the measured number, within the range that was stated.
By their numbers in this assay, from the lowest: compounds 2, 4, 3 and 1 (each within the scatter of the next, the first and the last beyond it).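

In this assay, among these compounds, the first comparison on the shared core that differs in one place gives a 1.1-fold lower number from compound 3 to compound 4 (0.03 log units; within the scatter), when 4-hydroxy-3-methoxyphenyl replaces 3-chlorophenyl. At this position, then, a larger aryl group carrying oxygen substituents and a hydrogen-bond donor cannot be told apart from a chlorinated one, so this exchange gives no measurable difference. Nothing available explains why these two groups read alike. As far as these compounds go, whether a phenyl ring bearing an amine or a carboxylic acid at this place would move beyond the scatter remains open.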